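Chloro in Place of Fluoro on a Shared Core

The compounds below may be only part of what the source reports. "The series", "measured", "known", "first", "only" and "open" are said of these compounds alone.

Measured compounds:
compound 1 `CS(=O)(=O)c1ccc(C2=NN(c3ccc(C(=O)O)cc3)C(c3ccccc3)C2)cc1`: 56.4%
compound 2 `CS(=O)(=O)c1ccc(C2=NN(c3ccc(C(=O)O)cc3)C(c3ccc(F)cc3)C2)cc1`: 42.3%

In a functional assay on the whole organism for inhibition, with Rattus norvegicus as the target, read by paw edema, with a stated time of 3 h, at a dose of 50 mg/kg by the oral route (on this read-out lower numbers stand for less inhibition and higher numbers for more inhibition at the one dose given (going by the name of the read-out)), compound 1 gives 56.4%, while compound 2 gives 42.3%. For the measured compounds named here, compound 2 stands lowest of the two numbers; the single measured step, a number 14.1 percentage points lower from compound 1 to compound 2 (beyond the scatter), separates it from compound 1 and lies beyond the scatter.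

Compound 3 `CS(=O)(=O)c1ccc(C2=NN(c3ccc(C(=O)O)cc3)C(c3ccc(Cl)cc3)C2)cc1` differs from compound 2 by chloro in place of fluoro on an aromatic carbon. Going by the values given here, no measured step exchanges one halogen for another. Among the compounds with values here, the only step recorded, a number 14.1 percentage points lower from compound 1 to compound 2 (beyond the scatter), concerns fluoro entering in place of hydrogen and does not bear directly on a swap of chloro for fluoro. With nothing in the data pointing either way, the read-out of compound 3 in this assay is expected to sit close to that of compound 2. The expected step is a number 2.7 percentage points higher from compound 2 to compound 3 (within the scatter). Compound 3 is therefore estimated at 45%, in a range from 30% to 60%.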

Compound 3, a percentage reported as inhibition, in the whole organism at one dose (the size of the read-out at that dose, not a potency): 50.4%
Estimate against measurement, compound 3: 5.4 percentage points below; low and high end bracket the measured number.
By their numbers in this assay, from the lowest: compounds 2, 3 and 1 (each within the scatter of the next, the first and the last beyond it).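

In this assay, 4-fluorophenyl giving way to 4-chlorophenyl yields a number 8.1 percentage points higher from compound 2 to compound 3 (within the scatter), so the two halogens cannot be told apart at this place on the aromatic ring. Chloro in place of hydrogen yields a number 6 percentage points lower from compound 1 to compound 3 (within the scatter), whereas fluoro in place of hydrogen had given a step beyond the scatter, so a halogen here does not always bring a clear drop, and compound 3 cannot be separated from either compound 1 or compound 2. Nothing at hand accounts for these numbers.

The compounds shown leave open how a bromo, a methoxy or an amine on the same aromatic carbon would read in this assay. They also leave open whether compound 1, compound 2 and compound 3 would stand as they do here at another dose.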